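The source may report more compounds than this note shows. Statements on the series, on what has been measured and on what is new or still open speak of the compounds shown alone.

Measured so far:
compound 1 `O=C(Nc1nccs1)c1cccc(Nc2ncc(F)c(Nc3ccc(F)cc3)n2)c1` — > 10000 nM
compound 2 `O=C(Nc1cc(Cl)cc(Cl)c1)c1cccc(Nc2ncc(F)c(Nc3ccc(F)cc3)n2)c1` — 17500 nM

Compound 1 carries a 1,3-thiazol-2-yl group on the amide-type nitrogen. In a functional assay on DU-145 cells (Homo sapiens) for antiproliferative activity, read by sulforhodamine B assay, with a stated time of 3 days (a higher number here means a weaker inhibitor of growth, a lower number a stronger inhibitor of growth), compound 1 gives only a limit, > 10000 nM, so its true value is not known. Going by the values given here, compound 2 is the only other measured member of the series, and in this assay compound 2 gives 17500 nM. The step that the limit leaves unreadable from compound 1 to compound 2 cannot be sized because of the limit of > 10000 nM in this assay, at which 1 of the 2 values shown sits; all that can be said is that both measured compounds sit at or near the weak end of this assay.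

Compound 3 `Cn1ccnc1NC(=O)c1cccc(Nc2ncc(F)c(Nc3ccc(F)cc3)n2)c1` differs from compound 1 in one place: 1-methyl-1H-imidazol-2-yl in place of 1,3-thiazol-2-yl on an amide-type nitrogen. Among the compounds with values here, no measured step shows this particular change, so the expectation rests only on where compound 1 and compound 2 stand. For compound 3 the expected step is a step that the limit leaves unreadable from compound 1 to compound 3, meaning no shift beyond the scatter is anticipated. Compound 3 is therefore estimated at 15000 nM in this assay, with a likely range from 5000 nM to 40000 nM, and a fair chance that only a limit is reported.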

Compound 3, concentration for 50% growth inhibition: 15100 nM
Beside the measured number, compound 3's estimate is 1.0-fold (0.00 log units) below it, within the range that was stated.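

In this assay, going by these compounds alone, replacing 3,5-dichlorophenyl on the amide-type nitrogen gives a 1.2-fold lower number from compound 2 to compound 3 (0.06 log units; within the scatter), so this change offers the first readable step at this position. The two groups cannot be told apart here, and both compound 2 and compound 3 stay at the weak end of the assay. The steps starting from compound 1 cannot be read, as its value is only a limit: the limit of > 10000 nM in this assay, at which 1 of the 3 values shown sits.

On these data alone, whether a longer chain ending in an amine, or a carboxylic acid, on the amide-type nitrogen would move the number beyond the scatter stays open. Also open, as far as these compounds go, is where compound 1 truly stands relative to compound 2 and compound 3, and so whether 1,3-thiazol-2-yl differs at all from the other two groups.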